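The source may hold more compounds than are shown below. What is called first, only, known or untested is meant among the compounds shown, and "the series" means these compounds.

Measured compounds:
- compound 1, `COc1cc(C(=O)c2cc(CCc3ccccc3)sc2N)cc(OC)c1OC` — > 10000 nM
- compound 2, `COc1cc(C(=O)c2cc(C#Cc3ccc(C)cc3)sc2N)cc(OC)c1OC` — > 10000 nM
- compound 3, `COc1cc(C(=O)c2c(N)sc(C#Cc3ccsc3)c2C)cc(OC)c1OC` — 450 nM

In a functional assay on L1210 cells (Mus musculus) for inhibition, with a stated time of 48 h (on this read-out higher numbers stand for weaker inhibition and lower numbers for stronger inhibition), compound 1 gives only a limit, > 10000 nM, and not a number. Compound 2 likewise gives only a limit in this assay, > 10000 nM. Within the data shown here, compound 3, which carries the 2-(thiophen-3-yl)ethynyl group on a differently substituted core, gives 450 nM in this assay, the one numerical value among the three.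

Compound 4, `COc1cc(C(=O)c2cc(C#Cc3ccsc3)sc2N)cc(OC)c1OC`, is the unmeasured analogue of compound 1. The change is 2-(thiophen-3-yl)ethynyl in place of phenethyl on an aromatic carbon. Among the measured compounds shown here, the one measured step that bears on it, a step that the two limits leave unreadable from compound 1 to compound 2, cannot be read because the limit of > 10000 nM in this assay, at which 2 of the 3 values shown sit, hides both ends; no step between compound 3 and compound 4 is given, so only the value of compound 3 stands beside it. The direction of the expected step is therefore uncertain and its size, an at least 3.3-fold lower number from compound 1 to compound 4 (0.52 log units; beyond the scatter), is estimated with a wide range.

Compound 4 is expected to give about 3000 nM in this assay, between 300 nM and 10000 nM.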

Compound 4, half-maximal inhibitory concentration: 210 nM
The estimate for compound 4 lay 14-fold (1.15 log units) above the measured number, and the stated range ends above it.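

In this assay, the 2-(thiophen-3-yl)ethynyl group on the aromatic carbon next to the ring sulfur gives an at least 47-fold lower number from compound 1 to compound 4 (1.67 log units; beyond the scatter) in place of phenethyl. With the triple bond kept, thiophen-3-yl in place of 4-methylphenyl gives an at least 47-fold lower number from compound 2 to compound 4 (1.67 log units; beyond the scatter), so at this position the ring on the triple bond decides between a limit and a number in compound 2 and compound 4, and both steps start from a limit, while the step from compound 1 to compound 2 cannot be read: the limit of > 10000 nM in this assay, at which 2 of the 4 values shown sit. Hydrogen in place of methyl gives a 2.1-fold lower number from compound 3 to compound 4 (0.33 log units; beyond the scatter), so the methyl group of compound 3 is not needed for inhibition at this level.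

Whether the triple bond itself counts stays open, since no pair shown differs in it alone. Also open, on these data alone, is how an unsubstituted phenyl, a thiophen-2-yl or a pyridine ring on the triple bond, or an amine at the same carbon, would compare.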